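A few compounds are considered here, and "the series" means these few. Any claim that something is new, unique, unknown or untested is made for them only; others in the source may bear on it.

Among the measured compounds shown here, in a functional assay on SK-BR-3 cells (Homo sapiens) for antiproliferative activity, read by MTT assay, with a stated time of 72 h (on this read-out higher numbers stand for weaker inhibition and lower numbers for stronger inhibition), compound 3 (`C/C=C1/[C@H](O[C@@H]2O[C@H](CO)[C@@H](O)[C@H](O)[C@H]2O)OC=C(C(=O)OC)[C@H]1CC(=O)OCCc1ccc(O)c(O)c1`) gives 160000 nM as the only actual number so far. Compound 1 (`C/C=C1/[C@H](O[C@@H]2O[C@H](CO)[C@@H](O)[C@H](O)[C@H]2O)OC=C(C(=O)OC)[C@H]1CC(=O)NCCC`) gives only a limit (> 20000 nM). Compound 2 (`C#CCOC(=O)C[C@@H]1C(C(=O)OC)=CO[C@@H](O[C@@H]2O[C@H](CO)[C@@H](O)[C@H](O)[C@H]2O)/C1=C/C`) also gives only a limit (> 15000 nM). The change to compound 4 (`C/C=C1/[C@H](O[C@@H]2O[C@H](CO)[C@@H](O)[C@H](O)[C@H]2O)OC=C(C(=O)OC)[C@H]1CC(=O)OCCc1ccccc1`) is this (phenyl in place of 3,4-dihydroxyphenyl on a saturated chain carbon, two bonds along the chain from an oxygen next to a carbonyl group): phenyl in place of 3,4-dihydroxyphenyl on a saturated chain carbon, two bonds along the chain from an oxygen next to a carbonyl group. The measured steps (a step that the two limits leave unreadable from compound 1 to compound 2; a step that the limit leaves unreadable from compound 1 to compound 3; a step that the limit leaves unreadable from compound 2 to compound 3) have no readable size, and none of them alters this group. The expectation therefore rests on compound 3 (160000 nM) alone, and no step beyond the scatter is expected in this assay (a 1.3-fold lower number from compound 3 to compound 4 (0.12 log units; within the scatter)). Compound 4 is estimated at 120000 nM (expected range 30000 nM to 400000 nM).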

Compound 4, half-maximal inhibitory concentration: 11000 nM
Estimate against measurement, compound 4: 11-fold (1.04 log units) above; measured number outside the range, below it.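

Phenyl in place of 3,4-dihydroxyphenyl, on a saturated chain carbon, two bonds along the chain from an oxygen next to a carbonyl group, gives the first readable step of the series in this assay: a 15-fold lower number from compound 3 to compound 4 (1.16 log units; beyond the scatter). Compounds 1 and 2 carry limits, so only floors can be read, an at least 1.3-fold lower number from compound 2 to compound 4 (0.13 log units; that floor lies within the scatter) and an at least 1.8-fold lower number from compound 1 to compound 4 (0.25 log units; that floor lies within the scatter), and neither shows compound 4 to be stronger. Nothing shown gives a cause for the large step. Still open, as far as these compounds go, is what a methoxy group or a fluorine on the phenyl ring would do in this assay. From the compounds shown here alone, a longer chain in place of phenethyl also remains open.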